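Swapping the Phenylethynyl Group for a Furan

A few compounds are considered here, and "the series" means these few. Any claim that something is new, unique, unknown or untested is made for them only; others in the source may bear on it.

Measured so far in a functional assay on Z-138 cells (Homo sapiens) for antiproliferative activity, with a stated time of 72 h; on this read-out higher numbers stand for weaker inhibition and lower numbers for stronger inhibition:
compound 1 `Nc1ncnn2c([C@@H]3O[C@H](CO)[C@@H](O)[C@H]3O)cc(C#CC3CC3)c12` gives 20 nM
compound 2 `Nc1ncnn2c([C@@H]3O[C@H](CO)[C@@H](O)[C@H]3O)cc(C#Cc3ccccc3)c12` gives 41400 nM

Compound 2 has the higher number of the two, so it is the weaker inhibitor. Compound 3 `Nc1ncnn2c([C@@H]3O[C@H](CO)[C@@H](O)[C@H]3O)cc(-c3ccoc3)c12`, not yet measured, carries furan-3-yl in place of 2-phenylethynyl on an aromatic carbon. Among the measured compounds shown here, the only measured step that bears on this, a 2100-fold higher number from compound 1 to compound 2 (3.32 log units; beyond the scatter), changed just the group on the triple bond and was large. Compound 3 has no triple bond, so that step is only a loose guide. The step expected in this assay is still large and downward, an estimated 280-fold lower number from compound 2 to compound 3 (2.44 log units; beyond the scatter) overall. Compound 3 is estimated at 150 nM, with an expected range of 10 nM to 5000 nM for now.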

Compound 3, half-maximal inhibitory concentration: 300 nM
Compound 3: the middle estimate sits 2.0-fold (0.30 log units) below what was measured; low and high end bracket the measured number.
By their numbers in this assay, from the lowest: compound 1; then compound 3; then compound 2.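

A triple bond is not required at this position: furan-3-yl in place of 2-phenylethynyl brings a 140-fold lower number from compound 2 to compound 3 (2.14 log units; beyond the scatter) and so recovers much of the inhibition. Furan-3-yl in place of 2-cyclopropylethynyl gives a 15-fold higher number from compound 1 to compound 3 (1.18 log units; beyond the scatter) and so falls short, which leaves compound 1 the strongest of the three. The compounds shown leave open whether a phenyl ring or an amine attached directly at this position would match furan-3-yl. No measurement offered here explains either step.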